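The source may report more compounds than this note shows. Statements on the series, on what has been measured and on what is new or still open speak of the compounds shown alone.

Measured so far in a physicochemical assay for lipophilicity, using the shake flask method, measured as octanol-water partition, at pH 7.4; a higher number here means a more lipophilic compound, a lower number a more polar compound:

Compound 1, `CN(C)CCCCOc1ccc(C(=O)/C=C/c2ccccc2)cc1`: 1.64
Compound 2, `CCCN(CCC)CCCCOc1ccc(C(=O)/C=C/c2ccccc2)cc1`: 1.95
Compound 3, `CCN(CC)CCCCCOc1ccc(C(=O)/C=C/c2ccccc2)cc1`: 1.84

Compound 3 is not set apart from either of the other two beyond the scatter: a number 0.20 log units higher from compound 1 to compound 3 (within the scatter) and a number 0.11 log units lower from compound 2 to compound 3 (within the scatter). Within the data shown here, the one step in this assay that clears the scatter is the amine enlargement alone, a number 0.31 log units higher from compound 1 to compound 2 (beyond the scatter), where the chain between the aromatic oxygen and the nitrogen was kept as it was.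

Compound 4, `CCCCN(CCCC)CCCCCCOc1ccc(C(=O)/C=C/c2ccccc2)cc1`, has not been measured. Against compound 3 the change is (dibutylamino)methyl in place of diethylamino on a saturated chain carbon, five bonds along the chain from an oxygen on an aromatic ring. The step bearing on it most directly is a number 0.31 log units higher from compound 1 to compound 2 (beyond the scatter), an amine enlargement of a similar kind that gave a modest rise; the chain extension by itself, a number 0.20 log units higher from compound 1 to compound 3 (within the scatter), and the combined swap a number 0.11 log units lower from compound 2 to compound 3 (within the scatter) both stayed within the scatter. Among the measured compounds shown here, since the change to compound 4 enlarges the amine further than any measured step and lengthens the chain as well, a rise in this assay is expected, larger than the one from compound 1 to compound 2 but still modest given how small the measured steps in this assay have been. For compound 4 the expected step is a number 0.46 log units higher from compound 3 to compound 4 (beyond the scatter). Compound 4 is therefore estimated at 2.3, with a range from 1.9 to 2.75.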

Compound 4, partition coefficient: 2.19
For compound 4 the middle estimate is 0.11 log units above the measured one; the range from low to high includes it.
By their numbers in this assay, from the lowest: compounds 1, 3, 2 and 4 (each within the scatter of the next, the first and the last beyond it).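

In this assay, (dibutylamino)methyl in place of diethylamino on a saturated chain carbon, five bonds along the chain from an oxygen on an aromatic ring, gives a number 0.35 log units higher from compound 3 to compound 4 (beyond the scatter), a modest step. This is the second step in the series to clear the scatter after a number 0.31 log units higher from compound 1 to compound 2 (beyond the scatter), and both exchange a smaller amine for a larger one, though a number 0.20 log units higher from compound 1 to compound 3 (within the scatter) goes against any rule that each enlargement at this end of the chain clears the scatter. Nothing on hand gives a cause for the new step.

Amine size and chain length change together from compound 3 to compound 4, so the share of each in the step stays unresolved, and a dibutylamino group on the shorter chain of compound 2 would be the direct test. Also open, on these data alone, is whether cyclic amines such as piperidine or morpholine, or a chain longer than that of compound 4, would continue the same trend in this assay.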